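Replacing a pyridinylsulfanyl arm with phenoxy on the core

The compounds below may be only part of what the source reports. "The series", "measured", "known", "first", "only" and "open" are said of these compounds alone.

Compound 1 `CCC(=O)Nc1ccc(OCc2cc3cnc(C#N)nc3n2CCC2CCCCC2)cc1` gives 12 nM in an assay on isolated protein for inhibition of cathepsin S (Homo sapiens), read by fluorescence; on this read-out higher numbers stand for weaker inhibition and lower numbers for stronger inhibition.
Compound 2 `N#Cc1ncc2cc(CSc3ccncc3)n(CCC3CCCCC3)c2n1` gives 6 nM in this assay.

Compound 2 holds the lowest of the two numbers shown in this assay, yet compound 1 sits within the scatter of it, so neither can be called the stronger inhibitor. Compound 3 `N#Cc1ncc2cc(COc3ccccc3)n(CCC3CCCCC3)c2n1` has not yet been tested. It differs from compound 2 by phenoxy in place of (pyridin-4-yl)sulfanyl on a saturated chain carbon bound to an aromatic carbon. For the measured compounds named here, no step between measured compounds covers this exchange, so the expectation rests on the two numbers alone. A modest weakening, not clearly beyond the scatter, is expected as a 2.5-fold higher number from compound 2 to compound 3 (0.40 log units; beyond the scatter). Compound 3 is thus estimated at 15 nM in this assay, within a range of 5 nM to 50 nM.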

Compound 3, half-maximal inhibitory concentration: 10 nM
Compound 3: the middle estimate sits 1.5-fold (0.18 log units) above what was measured; measured number inside the range.
By their numbers in this assay, from the lowest: compounds 2, 3 and 1 (each within the scatter of the next).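

In this assay, phenoxy in place of (pyridin-4-yl)sulfanyl on a saturated chain carbon bound to an aromatic carbon gives a 1.7-fold higher number from compound 2 to compound 3 (0.22 log units; within the scatter) and so does not separate these two arms at this position. Hydrogen in place of propanoylamino on an aromatic carbon gives a 1.2-fold lower number from compound 1 to compound 3 (0.08 log units; within the scatter) and so shows that the phenoxy arm stays within the scatter with or without that group. Nothing shown here gives a reason for either result.

As far as these compounds go, what remains open is whether an amine or a carboxylic acid in place of phenoxy on that carbon would give a step beyond the scatter.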